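A few compounds are considered here, and "the series" means these few. Any claim that something is new, unique, unknown or untested is made for them only; others in the source may bear on it.

Measured so far in a functional assay on Bel-7402 cells (Homo sapiens) for cytotoxicity, read by MTT assay; a higher number here means a weaker inhibitor, a lower number a stronger inhibitor:
compound 1, `CCn1cc(-c2nc3ccc([N+](=O)[O-])cc3o2)c(=O)c2cc(F)c(N3CCNC(C)C3)c(F)c21`: 1600 nM
compound 2, `CCn1cc(C(=O)Nc2ccccc2)c(=O)c2cc(F)c(N3CCNC(C)C3)c(F)c21`: 6000 nM

Compound 2 holds the higher of the two numbers in this assay, and compound 1 stands at a number lower by a margin beyond the usual scatter. Among the compounds with values here, compound 1 and compound 2 differ in more than one place, so no single-point step connects them, and the gap between them cannot be assigned to any one change.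

Compound 3, `CCn1cc(C(=O)Nc2ccccc2O)c(=O)c2cc(F)c(N3CCNC(C)C3)c(F)c21`, is the next member of the series. It differs from compound 2 by one change only: hydroxy in place of hydrogen on an aromatic carbon. Nothing in the measured set tests this change directly, so the expectation rests on compound 2 alone and on the size of change such a single added group usually brings. The expected step in this assay is a 1.5-fold lower number from compound 2 to compound 3 (0.18 log units; within the scatter), small and toward a lower number, with a result within the scatter of compound 2 not ruled out. Compound 3 is estimated at 4000 nM, within a range from 1500 nM to 12000 nM.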

Compound 3, half-maximal inhibitory concentration: > 50000 nM
Compound 3: a limit, no number; the forecaster's own chance of this, stated with the estimate: 10%; middle value at least 12-fold (1.09 log units) away from the limit.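

In this assay, the change from phenylcarbamoyl to (2-hydroxyphenyl)carbamoyl gives an at least 8.3-fold higher number from compound 2 to compound 3 (0.92 log units; beyond the scatter), the only single-change step among the compounds shown, and it shows that this ortho position on the anilide phenyl ring is not indifferent to substitution: one added hydroxy moves the number upward, beyond the scatter, rather than leaving it in place. The reading for compound 3 is a limit of the assay and not a number: the limit of > 50000 nM in this assay, at which 1 of the 3 values shown sits. From the compounds shown here alone, the step therefore fixes a direction and a minimum size, while its full size stays unknown, and the single-point comparison concerns only this hydroxy at this one position.

The compounds shown leave open whether the rise belongs to hydroxy itself or to any group at this position, which a methoxy group, a fluorine atom or an amine in the same place would help to separate. They also leave open whether hydroxy has the same effect elsewhere on the phenyl ring, and how the shared core would respond to it with another group in place of the phenylcarbamoyl.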